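Replacing the acid chain of compound 2 with an amide chain

The compounds below may be only part of what the source reports. "The series", "measured", "known", "first", "only" and "open" are said of these compounds alone.

Of the compounds shown here, three have been measured in a physicochemical assay for lipophilicity, read by HPLC, at pH 7.5; a higher number here means a more lipophilic compound, a lower number a more polar compound. Compound 1 `CC[C@@H](Nc1c(C#N)c(-c2ccc(-c3ncccc3C)cc2)nc2cnccc12)C(N)=O` gives 2, compound 2 `CCOc1ccccc1-c1ccc(-c2nc3cnccc3c(C[C@H](C)C(=O)O)c2C#N)cc1` gives 2.2, and compound 3 `CC[C@@H](Nc1c(C#N)c(-c2ccc(-c3ccc(Cl)cc3)cc2)nc2cnccc12)C(N)=O` gives 3.1. Compound 2 thus stands second highest of the three: its number and that of compound 1 lie within the scatter of each other, while compound 3 reads clearly higher. Among the compounds with values here, the one single-point step recorded, a number 1.10 log units higher from compound 1 to compound 3 (beyond the scatter), swaps one aryl group for another and does not touch the chain.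

Compound 4 `CCOc1ccccc1-c1ccc(-c2nc3cnccc3c(NC(COC)C(N)=O)c2C#N)cc1` differs from compound 2 as follows: (1-carbamoyl-2-methoxyethyl)amino in place of 2-carboxypropyl on an aromatic carbon. Within the data shown here, no measured step bears on this change directly. Among the measured compounds shown here, the only guide is that compounds 1 and 3 carry a chain that also ends in a carbamoyl group. Compound 1 reads 2 and compound 3 reads 3.1, which spans a range around and above compound 2. The step is therefore expected to be modest and upward, as a number 0.40 log units higher from compound 2 to compound 4 (beyond the scatter). For compound 4 the estimate in this assay is 2.6, with a range from 2 to 3.2.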

Compound 4, distribution coefficient: 2.8
Beside the measured number, compound 4's estimate is 0.20 log units below it, within the range that was stated.
By their numbers in this assay, from the lowest: compounds 1 and 2 (each within the scatter of the next); then compounds 4 and 3 (each within the scatter of the next).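

In this assay, the step of a number 0.60 log units higher from compound 2 to compound 4 (beyond the scatter) is the first one shown at this position, on the aromatic carbon opposite the ring nitrogen; the only earlier step changed a distant aryl group. It shows that the chain at this position can shift the number on its own, with the rest of compound 2 unchanged. The entering (1-carbamoyl-2-methoxyethyl)amino group has more heavy atoms and more hydrogen-bond donors and acceptors than 2-carboxypropyl, yet the number still rises, and no measurement shown explains why.

On these data alone, this single swap changes the chain's end group, its linking atom and its methoxy arm together, so the contribution of each remains open. A carboxylic acid on the same amino link, or a plain amine chain without the methoxy group, would help separate them.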